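This account rests on a few compounds, and the source may have more. Where it says the series, first, only, none or still open, it means among the compounds named here.

Compound 1 `FC(F)(F)c1cc(Nc2nc3nonc3nc2Nc2cc(C(F)(F)F)cc(C(F)(F)F)c2)cc(C(F)(F)F)c1` gives 6100 nM in an assay on mitochondria from L6 cells (Rattus norvegicus) for activation, with a stated time of 90 min; on this read-out higher numbers stand for an effect only at larger amounts of compound and lower numbers for an effect already at smaller amounts.
Compound 2 `CCOc1cccc(Nc2nc3nonc3nc2Nc2cccc(OCC)c2)c1` gives 10100 nM.
Compound 3 `Fc1ccccc1Nc1nc2nonc2nc1Nc1ccccc1` gives 2200 nM.

Of the compounds shown here, three sharing one core have been measured so far in this assay. Compound 3, with a fluorine on one aromatic ring and an unsubstituted phenyl on the other, gives the lowest number of the three at 2200 nM. Compound 1 stands nearest to it, at 6100 nM, a gap beyond the scatter; compound 2 stands furthest, at 10100 nM, also beyond the scatter. Among the measured compounds shown here, no pair among the measured compounds differs in only one place, so no single step has been measured directly.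

Compound 4 `Cc1ccccc1Nc1nc2nonc2nc1Nc1ccccc1F` is the next compound to be measured. It differs from compound 3 by methyl in place of hydrogen on an aromatic carbon, the methyl entering on an aromatic carbon of a six-membered aromatic ring of carbon only, ortho to a large group. The measured compounds give no guide to such a change, so the step is estimated to be small and of uncertain direction, likely within the scatter. Compound 4 is therefore expected to give about 2000 nM, within a range of 800 nM to 5000 nM, which amounts to an expected step of a 1.1-fold lower number from compound 3 to compound 4 (0.04 log units; within the scatter).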

Compound 4, half-maximal effective concentration: 1100 nM
Compound 4: the middle estimate sits 1.8-fold (0.26 log units) above what was measured; low and high end bracket the measured number.
By their numbers in this assay, from the lowest: compounds 4 and 3 (each within the scatter of the next); then compounds 1 and 2 (each within the scatter of the next).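

With compound 4, the series gains its first measured change in a single place. In this assay, methyl in place of hydrogen on an aromatic carbon, ortho to a large group, which turns phenyl into 2-methylphenyl, gives a 2.0-fold lower number from compound 3 to compound 4 (0.30 log units; within the scatter), so this position accepts a methyl group without a difference that can be told apart from the usual scatter of the read-out. The earlier compounds could not show this, as they differ from one another in more than one place, and nothing available explains how this position relates to the read-out.

The compounds shown leave open whether the same position would also accept a longer chain such as ethyl, or a methoxy group, a chlorine atom, an amine or a carboxylic acid, any of which might separate from compound 3 by more than the scatter. They also leave open whether methyl at this place would read the same without the fluorine on the other aromatic ring, since this single step gives no basis for a trend.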